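The source may report more compounds than this note shows. Statements on the series, on what has been measured and on what is new or still open speak of the compounds shown alone.

In an ADME assay on CHO cells (Cricetulus griseus) for cytotoxicity, read by MTT assay (a higher number here means that more compound is tolerated, a lower number that less compound is tolerated), compound 1 `CN1CCN(C2CCN(c3nccc4[nH]c(-c5cccc(OC(F)(F)F)c5)nc34)CC2)CC1` gives 3000 nM, compound 2 `CN1CCN(C2CCN(c3nccc4[nH]c(-c5ccc(F)c(C(F)(F)F)c5)nc34)CC2)CC1` gives 4800 nM and compound 3 `COC(=O)c1cccc(-c2nc3c(N4CCC(N5CCN(C)CC5)CC4)nccc3[nH]2)c1` gives 34000 nM. Compound 2 is not separated from its nearest neighbour, with a step of a 1.6-fold higher number from compound 1 to compound 2 (0.20 log units; within the scatter). The step to the top of the set is a 7.1-fold higher number from compound 2 to compound 3 (0.85 log units; beyond the scatter).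

Compound 4 `CN1CCN(CC2CCN(c3nccc4[nH]c(-c5ccc(F)c(C(F)(F)F)c5)nc34)CC2)CC1` keeps the aromatic group of compound 2. The change is (4-methylpiperazin-1-yl)methyl in place of 4-methylpiperazin-1-yl on a saturated ring carbon.

Every measured step alters the aromatic group, so none tests this position directly. The larger steps, an 11-fold higher number from compound 1 to compound 3 (1.05 log units; beyond the scatter) and the one above to the same compound, both bring in methoxycarbonyl, which compound 4 lacks. The data therefore give no direction, and no shift beyond the scatter is expected in this assay. The anchor remains compound 2 at 4800 nM.

The expected step is a 1.1-fold lower number from compound 2 to compound 4 (0.03 log units; within the scatter). For compound 4 the estimated value is 4500 nM, with an expected range of 2000 nM to 10000 nM.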

Compound 4, half-maximal cytotoxic concentration: 3100 nM
Beside the measured number, compound 4's estimate is 1.5-fold (0.16 log units) above it; the measured number falls inside the stated range.
By their numbers in this assay, from the lowest: compounds 1, 4 and 2 (each within the scatter of the next); then compound 3.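

Going by these compounds alone, with (4-methylpiperazin-1-yl)methyl in place of 4-methylpiperazin-1-yl, a 1.5-fold lower number from compound 2 to compound 4 (0.19 log units; within the scatter) in this assay gives the first reading at this saturated ring carbon, as every earlier step altered the aromatic group. For this pair, the change at a position three ring bonds from the ring nitrogen stays within the scatter, with the 4-fluoro-3-(trifluoromethyl)phenyl group held constant. No measurement at hand offers an explanation for this result.

A primary amine, a carboxylic acid or a longer chain carrying the 4-methylpiperazin-1-yl ring at this carbon remains an open test of how far the position tolerates change. Also open, on these data alone, is whether the 3-(methoxycarbonyl)phenyl group of compound 3, at 34000 nM, would hold that number alongside (4-methylpiperazin-1-yl)methyl.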